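Phenyl variation on the five-membered ring: antiproliferative working notes

This account rests on a few compounds, and the source may have more. Where it says the series, first, only, none or still open, it means among the compounds named here.

The series shares one core and varies the phenyl group sitting on an aromatic nitrogen of a five-membered aromatic ring with 3 nitrogen. Compound 1 `COc1ccc(-n2nncc2CN2C(=O)C3(C(C#N)=C(N)Oc4c3c3nc5ccccc5nc3c3ccccc43)c3ccccc32)cc1` carries a methoxy on the phenyl. In an ADME assay on HUVEC cells (Homo sapiens) for antiproliferative activity, read by MTT assay, with a stated time of 48 h (a lower number here means a stronger inhibitor, a higher number a weaker inhibitor), compound 1 gives > 50000 nM, which is a limit of the assay and not a number. Compound 2 `CCOc1ccc(-n2nncc2CN2C(=O)C3(C(C#N)=C(N)Oc4c3c3nc5ccccc5nc3c3ccccc43)c3ccccc32)cc1` carries an ethoxy instead. In this assay compound 2 gives > 50000 nM, again a limit. Compound 3 `CC(=O)Nc1ccc(-n2nncc2CN2C(=O)C3(C(C#N)=C(N)Oc4c3c3nc5ccccc5nc3c3ccccc43)c3ccccc32)cc1` carries an acetamido. In this assay compound 3 gives > 50000 nM, also a limit. The measured steps are therefore all unreadable: a step that the two limits leave unreadable from compound 1 to compound 2, a step that the two limits leave unreadable from compound 1 to compound 3 and a step that the two limits leave unreadable from compound 2 to compound 3. Compound 3 stands exactly where the whole measured set stands, namely at the limit of > 50000 nM in this assay, at which 3 of the 3 values shown sit.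

Compound 4 `Cc1ccc(C)c(-n2nncc2CN2C(=O)C3(C(C#N)=C(N)Oc4c3c3nc5ccccc5nc3c3ccccc43)c3ccccc32)c1` differs from compound 3 by 2,5-dimethylphenyl in place of 4-acetamidophenyl on an aromatic nitrogen. Among the compounds with values here, no measured step matches this exchange, and the three steps that do touch the phenyl group show no readable size. The expectation for compound 4 rests only on the fact that every measured value sits at the limit of > 50000 nM in this assay, at which 3 of the 3 values shown sit. Compound 4 is expected to give about 60000 nM in this assay, with a range from 20000 nM to 200000 nM. The estimated step that the limit leaves unreadable from compound 3 to compound 4 is thus expected to be none beyond the scatter, most likely another limit.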

Compound 4, half-maximal inhibitory concentration: > 50000 nM
Compound 4 gave a limit, no number (the forecaster's own chance of this, stated with the estimate: 85%); the middle value lies beyond the limit too.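

In this assay, compound 4 gives a limit and not a number, as do compound 1, compound 2 and compound 3, so none of the steps to compound 4 can be read: the limit of > 50000 nM in this assay, at which 4 of the 4 values shown sit.

The compounds shown leave open whether any phenyl group on this core gives a readable value in this assay, and how far these four compounds lie from one another.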